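The source may hold more compounds than are shown below. What is called first, only, known or untested is meant among the compounds shown, and "the series" means these compounds.

Measured compounds in an in vitro ADME assay on microsomes from liver (Homo sapiens) for metabolic stability, with a stated time of 15 min; a higher number here means faster removal of the compound, a lower number slower removal:
compound 1 `CCc1nn2c(-c3c(OC)cccc3OC)cccc2c1N(CC1CCOCC1)CC1CC1` gives 740 mL.min-1.g-1
compound 2 `COCc1cc(OC)c(-c2cccc3c(N(CC4CCOCC4)CC4CC4)c(OC)nn23)c(OC)c1` gives 760 mL.min-1.g-1
compound 3 `CCc1nn2c(-c3c(C)cc(C)cc3OC)cccc2c1N(CC1CC1)CC1CCOC1` gives 1350 mL.min-1.g-1

The three compounds share a core and differ in the substituents on the pendant aromatic ring and in the saturated ring carried on the nitrogen. In this assay, among the measured compounds shown here, the three numbers lie within the usual scatter of one another: the gap from compound 3 to compound 2 and the gap from compound 3 to compound 1 are both of a size that repeated measurements can produce on their own, so no compound separates from the rest, and compound 3 cannot be set apart from compounds 1 and 2 on these numbers.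

Compound 4 `CCc1nn2c(-c3c(C)cc(C)cc3OC)cccc2c1N(CC1CC1)CC1CCCO1` has not yet been run in this assay. It has the same atoms as compound 3, joined differently: oxolan-2-yl in place of oxolan-3-yl on a saturated chain carbon bound to a nitrogen on an aromatic ring. For the measured compounds named here, no measured pair in this set isolates that change, so the expectation rests on the observation that all three measured numbers sit close together despite larger differences in structure. The step from compound 3 to compound 4 is expected to be none beyond the scatter, no change at the digits printed from compound 3 to compound 4 (within the scatter). Compound 4 is therefore estimated at 1350 mL.min-1.g-1 in this assay, with a range from 700 mL.min-1.g-1 to 2700 mL.min-1.g-1.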

Compound 4, intrinsic clearance in microsomes: 1230 mL.min-1.g-1
Estimate against measurement, compound 4: 1.1-fold (0.04 log units) above, and the stated range covers the measured number.
By their numbers in this assay, from the lowest: compounds 1, 2, 4 and 3 (each within the scatter of the next).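

Within this assay, oxolan-2-yl in place of oxolan-3-yl on a saturated chain carbon bound to a nitrogen on an aromatic ring gives a 1.1-fold lower number from compound 3 to compound 4 (0.04 log units; within the scatter) and is the first step in the series confined to one place. The earlier compounds shown here differ in more than one place, so they could not speak to this position alone; with the rest of the structure held constant, moving the attachment point on the oxolane ring does not separate the two compounds in this read-out. Nothing available explains the result or indicates where on these compounds removal takes place.

Going by these compounds, only these two oxolane attachments have been compared at this position, so it remains open whether an amine or a carboxylic acid carried there, or a longer chain between the nitrogen and the ring, would give a step beyond the scatter. Also open, on these data alone, is whether the same change would read alike with the substituents on the pendant aromatic ring of compound 1 in place of those shared by compound 3 and compound 4.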